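Thiophene in Place of Dimethoxyphenyl on the Enone Carbonyl

The compounds below may be only part of what the source reports. "The series", "measured", "known", "first", "only" and "open" are said of these compounds alone.

Compound 3 `COc1ccc(-c2cc3ccccc3nc2/C=C/C(=O)c2ccc(OC)c(OC)c2)cc1` gives 4790 nM in a functional assay on MDA-MB-231 cells (Homo sapiens) for antiproliferative activity, read by XTT assay, with a stated time of 72 h (on this read-out higher numbers stand for weaker inhibition and lower numbers for stronger inhibition), the higher of the two numbers reported, though within the scatter of compound 2 `COc1ccc(-c2cc3ccccc3nc2/C=C/C(=O)c2ccc(OC)cc2OC)cc1`, which gives 3210 nM. The step of a 1.5-fold higher number from compound 2 to compound 3 (0.17 log units; within the scatter) is small. For compound 1 `COc1ccc(-c2cc3ccccc3nc2C=O)cc1`, this assay reports > 10000 nM, a limit of the assay rather than a number (the limit of > 10000 nM in this assay, at which 1 of the 3 values shown sits). Compound 4 `COc1ccc(-c2cc3ccccc3nc2/C=C/C(=O)c2cccs2)cc1` carries the change (thiophen-2-yl in place of 3,4-dimethoxyphenyl on a carbonyl carbon). For the measured compounds named here, the only measured step, from compound 2 to compound 3, swapped two methoxylated six-membered rings on the same carbonyl carbon and stayed within the scatter; no measured step replaces a six-membered aromatic ring of carbon only with a five-membered aromatic ring, so no direction can be derived. Compound 4 is therefore expected at 4800 nM (range 1600 nM to 14000 nM), a step of a 1.0-fold higher number from compound 3 to compound 4 (0.00 log units; within the scatter), essentially level with compound 3.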

Compound 4, half-maximal inhibitory concentration: 410 nM
Compound 4: the middle estimate sits 12-fold (1.07 log units) above what was measured, and the stated range ends above it.
By their numbers in this assay, from the lowest: compound 4; then compounds 2 and 3 (each within the scatter of the next). At a limit, above all of these: compound 1.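

On this carbonyl carbon the choice of ring does matter: the two dimethoxyphenyl isomers stayed within the scatter of each other, whereas thiophen-2-yl gives a 12-fold lower number from compound 3 to compound 4 (1.07 log units; beyond the scatter) and a 7.8-fold lower number from compound 2 to compound 4 (0.89 log units; beyond the scatter). The step of an at least 24-fold lower number from compound 1 to compound 4 (1.38 log units; beyond the scatter) is only a bound, as compound 1 carries a limit of the assay and not a number: the limit of > 10000 nM in this assay, at which 1 of the 4 values shown sits.

The compounds shown leave open whether the lower numbers follow from the five-membered ring, its sulfur or the absence of methoxy groups. A furan-2-yl or an unsubstituted phenyl on the same carbonyl carbon would separate these.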